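Swapping bromine for fluorine on the aromatic ring of compound 3

The source may hold more compounds than are shown below. What is called first, only, known or untested is meant among the compounds shown, and "the series" means these compounds.

Measured so far, in an ADME assay on isolated protein for inhibition of Amine oxidase [flavin-containing] B (Homo sapiens); on this read-out higher numbers stand for weaker inhibition and lower numbers for stronger inhibition:
compound 1 `C#CCNC1CCc2c(SCCc3cccc(C)c3)cccc21` gives 4960 nM;
compound 2 `C#CCNC1CCc2c(SCCc3ccc(C)cc3)cccc21` gives 4520 nM;
compound 3 `C#CCNC1CCc2c(SCCc3cccc(Br)c3)cccc21` gives 620 nM.

Compound 3 has the lowest number of the three. It differs from compound 1 by bromo in place of methyl on an aromatic carbon, a step of an 8.0-fold lower number from compound 1 to compound 3 (0.90 log units; beyond the scatter), and from compound 2 by a 7.3-fold lower number from compound 2 to compound 3 (0.86 log units; beyond the scatter); compounds 1 and 2 are within the scatter of each other a 1.1-fold lower number from compound 1 to compound 2 (0.04 log units; within the scatter).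

Compound 4 `C#CCNC1CCc2c(SCCc3cccc(F)c3)cccc21` carries the change (fluoro in place of bromo on an aromatic carbon). Both steps into compound 3 show that a halogen there lowered the number against methyl; fluoro is another halogen, though a smaller one, so a smaller step back up in this assay is expected: a 2.4-fold higher number from compound 3 to compound 4 (0.38 log units; beyond the scatter). Compound 4 is thus estimated at 1500 nM, between 600 nM and 4000 nM.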

Compound 4, half-maximal inhibitory concentration: 7810 nM
Compound 4: the middle estimate sits 5.2-fold (0.72 log units) below what was measured; measured number above the stated range.
By their numbers in this assay, from the lowest: compound 3; then compounds 2, 1 and 4 (each within the scatter of the next).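

In this assay the two halogens do not behave alike at this position: fluoro in place of bromo gives a 13-fold higher number from compound 3 to compound 4 (1.10 log units; beyond the scatter) and ties the low number of compound 3 to bromo, not to halogens in general. Against the methyl compounds the steps are a 1.6-fold higher number from compound 1 to compound 4 (0.20 log units; within the scatter) and a 1.7-fold higher number from compound 2 to compound 4 (0.24 log units; within the scatter) and so, among these four compounds, only the bromo compound stands apart. Nothing available here explains the gap between bromo and fluoro. On these data alone, whether chloro or iodo on this aromatic carbon would follow bromo or fluoro stays open, as does the effect of trifluoromethyl or methoxy there.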